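Exchanging a Pyridin-3-yl Group for an Isopropylcarbamoyl Group

The source may report more compounds than this note shows. Statements on the series, on what has been measured and on what is new or still open speak of the compounds shown alone.

Compound 3 `O=C(O)c1ccc2noc(-c3ccc(-c4cccnc4)cc3)c2c1` gives 54 nM in an assay for inhibition of inositol hexakisphosphate kinase 2 (Homo sapiens), read by colorimetric assay, coupled enzyme assay and malachite green, with a stated time of 120 min, in the presence of a further agent that is not named here (on this read-out higher numbers stand for weaker inhibition and lower numbers for stronger inhibition), the lowest of the three numbers in hand; compound 2 `O=C(O)/C=C/c1ccc2noc(-c3ccc(-c4ccccc4)cc3)c2c1` gives 74 nM, within the scatter of it, while compound 1 `O=C(O)/C=C/c1ccc2noc(-c3ccc(OC(F)(F)F)cc3)c2c1` gives 320 nM, beyond the scatter. Compound 4 `CC(C)NC(=O)c1ccc(-c2onc3ccc(C(=O)O)cc23)cc1` carries isopropylcarbamoyl in place of pyridin-3-yl on an aromatic carbon. Among the measured compounds shown here, the only measured step at this place is a 4.3-fold lower number from compound 1 to compound 2 (0.64 log units; beyond the scatter), a modest one in the stronger direction, which shows that the group in this position does move the number. For the measured compounds named here, no measured step exchanges a ring for an amide, so the size of that exchange is unknown. The step of a 2.2-fold higher number from compound 3 to compound 4 (0.35 log units; beyond the scatter) is therefore expected to be small and toward weaker inhibition. Compound 4 is estimated at 120 nM, with a range from 40 nM to 400 nM.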

Compound 4, half-maximal inhibitory concentration: 350 nM
Compound 4: middle estimate off by 2.9-fold (0.46 log units), on the low side; measured number inside the range.
By their numbers in this assay, from the lowest: compounds 3 and 2 (each within the scatter of the next); then compounds 1 and 4 (each within the scatter of the next).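

At this place, on an aromatic carbon para to a large group, the exchange of a ring for an open amide is now measured: a 6.5-fold higher number from compound 3 to compound 4 (0.81 log units; beyond the scatter). It runs toward weaker inhibition, so the position moves the number in both directions, whereas the earlier step at this place ran only toward stronger inhibition. No measurement to hand bears on why this exchange raises the number.

Still open, as far as these compounds go, is whether the lost pyridin-3-yl ring or the isopropyl part of the amide sets this step. A plain carboxamide, a dimethylamino group or a pyrimidine ring at this place could separate the two.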